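Ring-to-chain swaps on the aryl nitrogen

The source may report more compounds than this note shows. Statements on the series, on what has been measured and on what is new or still open speak of the compounds shown alone.

Going by the values given here, compound 1 `[O-][S+]1CC(Nc2nonc2/C(=N/O)Nc2ccc(F)c(Br)c2)C1` gives 212 nM in an assay on isolated protein for inhibition of Indoleamine 2,3-dioxygenase 1 (Homo sapiens), read by fluorescence, with a stated time of 60 min (on this read-out higher numbers stand for weaker inhibition and lower numbers for stronger inhibition), the highest of the two numbers so far. Compound 2 `NS(=O)(=O)CCCNc1nonc1/C(=N/O)Nc1ccc(F)c(Br)c1` gives 126 nM in this assay. Among the compounds with values here, the single measured step, a 1.7-fold lower number from compound 1 to compound 2 (0.23 log units; within the scatter), puts a group with no ring in place of the ring. Compound 3 `NS(=O)(=O)CCONc1nonc1/C(=N/O)Nc1ccc(F)c(Br)c1` is made from compound 1 by a group of 7 heavy atoms (2 carbon, 1 nitrogen, 3 oxygen, 1 sulfur; no ring) in place of a group of 5 heavy atoms (3 carbon, 1 oxygen, 1 sulfur; one four-membered non-aromatic ring with 1 hetero atom), on a nitrogen on an aromatic ring. Within the data shown here, only that one step bears on this change, and it stayed within the scatter, so no movement beyond the scatter is expected here. Compound 3 is expected to give 150 nM, within 60 nM to 400 nM. The expected step is a 1.4-fold lower number from compound 1 to compound 3 (0.15 log units; within the scatter).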

Compound 3, half-maximal inhibitory concentration: 87 nM
For compound 3 the middle estimate is 1.7-fold (0.24 log units) above the measured one, and the stated range covers the measured number.
By their numbers in this assay, from the lowest: compounds 3, 2 and 1 (each within the scatter of the next, the first and the last beyond it).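

In this assay, going by these compounds alone, 2-sulfamoylethoxy gives the first step at this nitrogen that clears the scatter, a 2.4-fold lower number from compound 1 to compound 3 (0.39 log units; beyond the scatter), so an open chain in place of the four-membered ring can move the number. Between the two open chains, 2-sulfamoylethoxy and 3-sulfamoylpropyl, the step stays within the scatter, a 1.4-fold lower number from compound 2 to compound 3 (0.16 log units; within the scatter), so the assay does not separate them. Nothing measured here accounts for either step.

Open: whether a carboxylic acid or an amine in place of the sulfamoyl group holds the number, and how a longer chain on this nitrogen behaves.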